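Removing the fluoromethyl from the aryl urea of compound 2

A few compounds are considered here, and "the series" means these few. Any claim that something is new, unique, unknown or untested is made for them only; others in the source may bear on it.

Measured compounds:
compound 1 `CCCNc1cc(Oc2ccc(NC(=O)Nc3cccc(C(F)(F)F)c3)cc2)ncn1` 32 nM
compound 2 `CNc1cc(Oc2ccc(NC(=O)Nc3cccc(CF)c3)cc2)ncn1` 400 nM
compound 3 `COc1cc(Oc2ccc(NC(=O)Nc3cccc(C(F)(F)F)c3)cc2)ncn1` 4000 nM

In an assay on isolated protein for inhibition of serine/threonine-protein kinase TNNI3K (Homo sapiens) (a lower number here means a stronger inhibitor, a higher number a weaker inhibitor), compound 2 stands second highest of the three numbers; compound 3 lies nearest, compound 1 furthest, both beyond the scatter. Compound 4 `CNc1cc(Oc2ccc(NC(=O)Nc3ccccc3)cc2)ncn1` differs from compound 2 by hydrogen in place of fluoromethyl on an aromatic carbon. Among the compounds with values here, the only single-point step among the measured compounds, a 130-fold higher number from compound 1 to compound 3 (2.10 log units; beyond the scatter), concerns a different part of the structure and does not bear on this change; compound 1 and compound 2 differ in two places, so their values alone cannot isolate the fluoromethyl. Within the data shown here, with no guiding step, compound 4 is expected to give a somewhat higher number, a 3.0-fold higher number from compound 2 to compound 4 (0.48 log units; beyond the scatter), with the estimate for compound 4 placed at 1200 nM within a range from 400 nM to 4000 nM.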

Compound 4, half-maximal inhibitory concentration: 6300 nM
Estimate against measurement, compound 4: 5.3-fold (0.72 log units) below; the whole stated range lies below it.
By their numbers in this assay, from the lowest: compound 1; then compound 2; then compounds 3 and 4 (each within the scatter of the next).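

Replacing fluoromethyl with hydrogen on the aromatic carbon gives, in this assay, a 16-fold higher number from compound 2 to compound 4 (1.20 log units; beyond the scatter), a large step. Within the data shown here, this is the first single change read at this position, and it shows that the group on this ring carbon, meta to a large group, matters strongly for the number of compound 2. Among these compounds, the earlier compounds could not show this, as their only step concerned a different part of the structure. Nothing at hand explains the size of this step. As far as these compounds go, it remains open whether a chlorine atom, a nitrile or a methoxy group here would match fluoromethyl, and whether removing the trifluoromethyl from compound 1 would give a similar step.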